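This account rests on a few compounds, and the source may have more. Where it says the series, first, only, none or still open, it means among the compounds named here.

Among the measured compounds shown here, in a functional assay on K562 cells (Homo sapiens) for antiproliferative activity, read by CCK-8 assay, with a stated time of 72 h (on this read-out higher numbers stand for weaker inhibition and lower numbers for stronger inhibition), compound 1 `Cc1cc(Nc2cc(N3CCN(C)CC3)nc(Nc3ccc(S(N)(=O)=O)cc3)n2)n[nH]1` gives 1430 nM, the higher of the two numbers measured so far and therefore the weaker inhibition. The other measured compound, compound 2 `Cc1cc(Nc2cc(N3CCN(C)CC3)nc(Nc3ccc(Cl)cc3)n2)n[nH]1`, gives 192 nM. Compound 3 `Cc1cc(Nc2cc(N3CCN(C)CC3)nc(Nc3cccc([N+](=O)[O-])c3)n2)n[nH]1` has not yet been measured. It keeps the core of compound 1 and differs in one place, on a nitrogen on an aromatic ring: 3-nitrophenyl in place of 4-sulfamoylphenyl on a nitrogen on an aromatic ring. For the measured compounds named here, the one measured step that bears on this also removes sulfamoyl: chloro in place of sulfamoyl on an aromatic carbon gave a 7.4-fold lower number from compound 1 to compound 2 (0.87 log units; beyond the scatter), modest but beyond the scatter. Going by the values given here, no measured compound carries 3-nitrophenyl, so in this assay a move in the same direction, towards a lower number, is expected, though smaller than the move to compound 2 at 192 nM. The expected change is a 3.4-fold lower number from compound 1 to compound 3 (0.53 log units; beyond the scatter). For compound 3 the estimated value is 420 nM, with a range of 130 nM to 1350 nM.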

Compound 3, half-maximal inhibitory concentration: 138 nM
The estimate for compound 3 lay 3.0-fold (0.48 log units) above the measured number, and the stated range covers the measured number.
By their numbers in this assay, from the lowest: compounds 3 and 2 (each within the scatter of the next); then compound 1.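

Placing 3-nitrophenyl in place of 4-sulfamoylphenyl on a nitrogen on an aromatic ring gives a 10-fold lower number from compound 1 to compound 3 (1.02 log units; beyond the scatter) in this assay, so a second, quite different replacement for 4-sulfamoylphenyl also lowers the number, and this time the step is large. The other new step, a 1.4-fold lower number from compound 2 to compound 3 (0.14 log units; within the scatter), lies within the scatter, so 3-nitrophenyl and 4-chlorophenyl cannot be told apart in this assay at this place. Nothing available explains why compound 1 stands apart from compound 2 and compound 3.

On these data alone, it remains open whether other groups on this phenyl ring would also give low numbers, or whether only some do. A phenyl ring carrying an amine or a carboxylic acid at this place would test how far the result with compound 2 and compound 3 extends.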